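Aryl swap from compound 3 to compound 4

The source may report more compounds than this note shows. Statements on the series, on what has been measured and on what is new or still open speak of the compounds shown alone.

Measured in a functional assay on CCRF-CEM cells (Homo sapiens) for antiproliferative activity; a lower number here means a stronger inhibitor, a higher number a weaker inhibitor:
- compound 1 `COc1ccc(-c2cc(N)c(C(=O)c3cc(OC)c(OC)c(OC)c3)s2)cc1OC`: 20 nM
- compound 2 `COc1cc(C(=O)c2sc(-c3ccc(Cl)cc3)cc2N)cc(OC)c1OC`: 70 nM
- compound 3 `COc1cc(C(=O)c2sc(-c3ccccc3Cl)cc2N)cc(OC)c1OC`: 16 nM

The 2-chlorophenyl member shares the low end of the series: the numbers show a 1.3-fold lower number from compound 1 to compound 3 (0.10 log units; within the scatter), and also a 4.4-fold lower number from compound 2 to compound 3 (0.64 log units; beyond the scatter).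

Unmeasured compound 4 `COc1cc(C(=O)c2sc(-c3ccc(F)cc3)cc2N)cc(OC)c1OC` carries 4-fluorophenyl in place of 2-chlorophenyl on an aromatic carbon. For the measured compounds named here, no fluorine-bearing analogue has been measured. Compound 2, with its 4-chlorophenyl, is the closest measured analogue at 70 nM. The step in this assay is therefore expected to be modest and towards a higher number, about the size of a 4.4-fold lower number from compound 2 to compound 3 (0.64 log units; beyond the scatter) read backwards. The estimated change is a 3.4-fold higher number from compound 3 to compound 4 (0.54 log units; beyond the scatter). Compound 4 is expected at 55 nM, with an estimated range of 20 nM to 150 nM.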

Compound 4, half-maximal inhibitory concentration: 15 nM
Estimate against measurement, compound 4: 3.7-fold (0.56 log units) above, and the stated range ends above it.
By their numbers in this assay, from the lowest: compounds 4, 3 and 1 (each within the scatter of the next); then compound 2.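

With this assay as the read-out, fluoro in place of chloro on the phenyl is a clear step (a 4.7-fold lower number from compound 2 to compound 4 (0.67 log units; beyond the scatter)), so a halogen on that phenyl does not by itself bring the higher number of compound 2. The 2-chlorophenyl is not needed to reach the low end of the series (a 1.1-fold lower number from compound 3 to compound 4 (0.03 log units; within the scatter)). The 3,4-dimethoxyphenyl is not needed either (a 1.3-fold lower number from compound 1 to compound 4 (0.12 log units; within the scatter)), so three different aryl groups now sit together, with compound 2 the one that goes against them.

As far as these compounds go, whether 4-bromophenyl or 4-methylphenyl would follow compound 4 or compound 2 stays open. Nothing available explains the gap between the fluoro and chloro compounds.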